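A few compounds are considered here, and "the series" means these few. Any claim that something is new, unique, unknown or untested is made for them only; others in the source may bear on it.

Working notes on the series. Compound 1 `COC(=O)/C=C/c1cccc(N(Cc2ccc(/C=C/C(=O)OC(C)(C)C)cc2OC)C(=O)C2CCCCC2)c1` and compound 2 `COC(=O)/C=C/c1cccc(N(Cc2ccc(/C=C/C(=O)OC(C)(C)C)cc2OC(=O)c2ccccc2)C(=O)C2CCCCC2)c1` share one core and differ only at one oxygen on an aromatic ring. In an assay on isolated protein with Bile acid receptor (Homo sapiens) as the target (on this read-out higher numbers stand for an effect only at larger amounts of compound and lower numbers for an effect already at smaller amounts), compound 1 returns no number but a limit, > 1000 nM. In this assay compound 2 likewise stands only at a limit, > 1000 nM. As far as these compounds go, the step that the two limits leave unreadable from compound 1 to compound 2 therefore cannot be read; its size stays open. All that is known of where compound 2 stands is the limit of > 1000 nM in this assay, at which 2 of the 2 values shown sit.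

Compound 3 `CCOC(=O)COc1cc(/C=C/C(=O)OC(C)(C)C)ccc1CN(C(=O)C1CCCCC1)c1cccc(/C=C/C(=O)OC)c1` is the next member, not yet measured in this assay. Its change against compound 2 is (ethoxycarbonyl)methyl in place of benzoyl on an oxygen on an aromatic ring. Within the data shown here, no measured step bears on this change: the only step in the set, from compound 1 to compound 2, is hidden by the two limits, so no direction and no size can be taken from it.

Compound 3 is accordingly expected near the same limit, with the step that the limit leaves unreadable from compound 2 to compound 3 being the guess rather than a reading. The estimate for compound 3 in this assay is 2000 nM, within 400 nM to 10000 nM.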

Compound 3, half-maximal effective concentration: > 1000 nM
Compound 3: only a limit was reported; the forecaster's own chance of this, stated with the estimate: 70%; the middle value is on the limit's open side.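

In this assay compound 3 also gives only a limit, > 1000 nM. Among these compounds, no new step can therefore be read from compound 1 or compound 2 to compound 3. The compounds shown leave open whether methyl, benzoyl or (ethoxycarbonyl)methyl on an oxygen on an aromatic ring makes any difference in this assay, and what actual value each compound has.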